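This account rests on a few compounds, and the source may have more. Where it says the series, first, only, none or still open, it means among the compounds named here.

Values in a functional assay on WM164 cells (Homo sapiens) for antiproliferative activity, read by sulforhodamine B assay, with a stated time of 48 h; on this read-out higher numbers stand for weaker inhibition and lower numbers for stronger inhibition:
- compound 1 `CCCCCCCCCCCCNC(=O)[C@@H]1CSC(c2ccc(NC(C)=O)cc2)N1`: 1200 nM
- compound 2 `CCCCCCCCCCCCCCCCNC(=O)[C@@H]1CSC(c2ccc(NC(C)=O)cc2)N1`: 600 nM
- compound 3 `CCCCCCCCCCCCCCCCCCNC(=O)[C@@H]1CSC(c2ccc(NC(C)=O)cc2)N1`: 11600 nM

Compound 3 has the highest number of the three and is the weakest in this assay, with its steps to both others beyond the scatter. The next compound, compound 4 `CCCCCCCCC/C=C\CCCCCCCNC(=O)[C@@H]1CSC(c2ccc(NC(C)=O)cc2)N1`, differs from it by a group of 11 heavy atoms (11 carbon; no ring) in place of a group of 11 heavy atoms (11 carbon; no ring), on a saturated chain carbon, seven bonds along the chain from an amide-type nitrogen. The undecyl group leaves, and the entering group carries a double bond, on a saturated chain carbon, seven bonds along the chain from an amide-type nitrogen.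

Within the data shown here, the relevant measured steps all concern saturated chains, and none introduces a double bond, so there is no direct precedent. The first, a 2.0-fold lower number from compound 1 to compound 2 (0.30 log units; within the scatter), shows no clear change. The other two are a 9.7-fold higher number from compound 1 to compound 3 (0.99 log units; beyond the scatter) and a 19-fold higher number from compound 2 to compound 3 (1.29 log units; beyond the scatter). With the large 19-fold higher number from compound 2 to compound 3 (1.29 log units; beyond the scatter) as the nearest guide, a partial return towards lower numbers is expected, with wide uncertainty.

The expected change is a 4.1-fold lower number from compound 3 to compound 4 (0.62 log units; beyond the scatter). For compound 4 the estimated value is 2800 nM, with an expected range of 700 nM to 11000 nM.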

Compound 4, half-maximal inhibitory concentration: 1000 nM
The estimate for compound 4 lay 2.8-fold (0.45 log units) above the measured number, within the range that was stated.
By their numbers in this assay, from the lowest: compounds 2, 4 and 1 (each within the scatter of the next); then compound 3.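

Working notes on the series: in this assay, replacing undecyl with a group of equal heavy-atom count that carries one double bond gives a 12-fold lower number from compound 3 to compound 4 (1.06 log units; beyond the scatter), so at this place on the chain the heavy-atom count alone does not set the result. Compound 4 stands level with the other two saturated-chain compounds, with a 1.7-fold higher number from compound 2 to compound 4 (0.22 log units; within the scatter) and a 1.2-fold lower number from compound 1 to compound 4 (0.08 log units; within the scatter), both within the scatter. No available evidence bears on the reason for this result.

Going by these compounds, only one chain with a double bond appears here, so it remains open whether the double bond's geometry or its place along the chain matters. A trans double bond, a triple bond or a longer chain with a double bond would address this.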